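A few compounds are considered here, and "the series" means these few. Any claim that something is new, unique, unknown or untested is made for them only; others in the source may bear on it.

Measured so far:
Compound 1 `COc1ccc(-c2nc(/N=C(\N)NC(C)C)sc2-c2ccc(OC)cc2)cc1` gives 9.1 uM.
Compound 2 `COc1ccc(-c2nc(/N=C(\N)N(C)C)sc2-c2ccc(OC)cc2)cc1` gives 4.8 uM.
Compound 3 `COc1ccc(-c2nc(CNC(=O)N3CCOCC3)sc2-c2ccc(OC)cc2)cc1` gives 12 uM.

In a functional assay (aorta) with Rattus norvegicus as the target (on this read-out lower numbers stand for an effect already at smaller amounts and higher numbers for an effect only at larger amounts of compound), compound 1 stands second highest of the three numbers; its nearest neighbour is compound 3, with a 1.3-fold higher number from compound 1 to compound 3 (0.12 log units; within the scatter), and the furthest is compound 2, with a 1.9-fold lower number from compound 1 to compound 2 (0.28 log units; within the scatter). Compound 4 `CNC(=O)NCc1nc(-c2ccc(OC)cc2)c(-c2ccc(OC)cc2)s1` differs from compound 1 by a group of 6 heavy atoms (3 carbon, 2 nitrogen, 1 oxygen; no ring) in place of a group of 7 heavy atoms (4 carbon, 3 nitrogen; no ring), on an aromatic carbon. Among the measured steps, the one from compound 1 to compound 3 bears on this most closely, since there too a urea-bearing group replaced the group that leaves, and it was within the scatter. The step from compound 2 to compound 3 was a 2.5-fold higher number from compound 2 to compound 3 (0.40 log units; beyond the scatter), modest. The account therefore expects no step beyond the scatter in this assay, a 1.1-fold higher number from compound 1 to compound 4 (0.04 log units; within the scatter). Compound 4 is estimated at 10 uM, within 4.5 uM to 24 uM.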

Compound 4, concentration for half-maximal effect: 15 uM
Compound 4: middle estimate off by 1.5-fold (0.18 log units), on the low side; the measured number falls inside the stated range.
By their numbers in this assay, from the lowest: compounds 2, 1, 3 and 4 (each within the scatter of the next, the first and the last beyond it).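

In this assay, methylamino in place of morpholin-4-yl on the carbonyl carbon gives a step within the scatter (a 1.3-fold higher number from compound 3 to compound 4 (0.10 log units; within the scatter)), and so does the exchange of the whole group on this aromatic carbon (a 1.6-fold higher number from compound 1 to compound 4 (0.22 log units; within the scatter)). Compound 2 alone is set apart from both urea-bearing compounds, and the new step to compound 4 is modest (a 3.1-fold higher number from compound 2 to compound 4 (0.49 log units; beyond the scatter)). Nothing at hand explains these steps. From the compounds shown here alone, whether a carboxylic acid or a primary amine on this aromatic carbon, or an ethyl or longer chain in place of the methyl on the urea, would give a step beyond the scatter from compound 4 stays open.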